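Swapping chloro for methyl on a weak growth inhibitor

The compounds below may be only part of what the source reports. "The series", "measured", "known", "first", "only" and "open" are said of these compounds alone.

Measured in an ADME assay on HEK-293T cells (Homo sapiens) for inhibition, read by CCK-8 assay, with a stated time of 48 h, tested at 20 uM; a lower number here means less inhibition of growth, a higher number more inhibition of growth at the concentration tested:
compound 1 `COc1ccc(S(=O)(=O)Oc2ccccc2/C=C(\C#N)C(=O)Nc2nnc(Cc3ccc(Cl)cc3)s2)cc1`: 26%
compound 2 `N#C/C(=C\c1ccccc1OS(=O)(=O)c1ccc(F)cc1)C(=O)Nc1nnc(Cc2ccc(Cl)cc2)s1`: 14%

Of these two, compound 2 has the lower number, at 14%. Compound 3 `Cc1ccc(Cc2nnc(NC(=O)/C(C#N)=C/c3ccccc3OS(=O)(=O)c3ccc(F)cc3)s2)cc1` differs from it in one place: methyl in place of chloro on an aromatic carbon. Among the compounds with values here, the only measured step, a number 12 percentage points lower from compound 1 to compound 2 (beyond the scatter), was modest and swapped fluoro for methoxy elsewhere in the molecule. Within the data shown here, no measured step covers methyl in place of chloro, so that step offers only a rough sense of scale, and no step beyond the scatter is expected in this assay. The estimated step is a number 1 percentage points higher from compound 2 to compound 3 (within the scatter). Compound 3 is expected at 15%, with an estimated range of 4% to 28%.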

Compound 3, percent growth inhibition at one concentration: 11%
The estimate for compound 3 lay 4 percentage points above the measured number, within the range that was stated.
By their numbers in this assay, from the lowest: compounds 3 and 2 (each within the scatter of the next); then compound 1.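

Changing 4-chlorobenzyl to 4-methylbenzyl gives, in this assay, a number 3 percentage points lower from compound 2 to compound 3 (within the scatter). At this position, chloro and methyl cannot be told apart in this read-out, unlike the fluoro-for-methoxy change made elsewhere in the molecule, which gave a number 12 percentage points lower from compound 1 to compound 2 (beyond the scatter). Nothing measured here offers an explanation for this result.

As far as these compounds go, whether a more different group at this position, such as an amine or a carboxylic acid, would shift growth inhibition remains open. So does whether chloro and methyl would also match in the methoxy compound, compound 1.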